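The compounds below may be only part of what the source reports. "The series", "measured", "known", "first", "only" and "open" are said of these compounds alone.

Compound 1 `O=CN1CCN(c2ccc(Cl)cc2)C1=S` is one of two compounds with a growth inhibition value on the melanoma cell line. In a functional assay on M14 cells (Homo sapiens) for inhibition, read by sulforhodamine B assay, with a stated time of 48 h (on this read-out lower numbers stand for stronger inhibition of growth and higher numbers for weaker inhibition of growth), compound 1 gives 14600 nM, the higher of the two numbers. The other, compound 2 `N#C/C(=C\N1CCN(C(=O)c2ccco2)C1=S)C(=O)Nc1ccc(Cl)cc1`, gives 14200 nM in this assay, and the two values lie within the scatter of repeated measurements of each other, so nothing separates them.

Compound 3 `O=CN1CCN(c2ccc(Cl)c(Cl)c2)C1=S` has not yet been measured in this assay. It differs from compound 1 by a single change: chloro in place of hydrogen on an aromatic carbon.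

Among the measured compounds shown here, no pair of measured compounds traces this kind of change, so the expected step rests on the weak growth inhibition of compound 1 alone. The step expected from the value of compound 1 is a 1.5-fold lower number from compound 1 to compound 3 (0.16 log units; within the scatter), which would not pass beyond the usual scatter. Compound 3 is therefore estimated to give about 10000 nM in this assay, within a range from 4000 nM to 30000 nM.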

Compound 3, concentration for 50% growth inhibition: 16800 nM
For compound 3 the middle estimate is 1.7-fold (0.23 log units) below the measured one, within the range that was stated.
By their numbers in this assay, from the lowest: compounds 2, 1 and 3 (each within the scatter of the next).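

In this assay, placing chloro on an aromatic carbon ortho to the existing chloro group gives a 1.2-fold higher number from compound 1 to compound 3 (0.06 log units; within the scatter), so compound 1 and compound 3 cannot be told apart. Among the compounds shown here, this is the first direct reading of the change, and it shows that a second chloro at this position on the six-membered aromatic ring does not bring growth inhibition beyond the scatter. Nothing measured here offers an explanation for this result.

From the compounds shown here alone, whether a different group at this position, such as an amine, a carboxylic acid or a longer chain, would separate from compound 1 remains open. The compounds shown also leave open whether chloro at another place on the ring would read any differently.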